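The source may report more compounds than this note shows. Statements on the series, on what has been measured and on what is new or still open speak of the compounds shown alone.

Measured in a functional assay on the whole organism (Hindlimb, strain albino) with Mus musculus as the target, in the maximal electroshock model, with a stated time of 0.5 h; on this read-out lower numbers stand for an effect already at smaller amounts and higher numbers for an effect only at larger amounts of compound:
- Compound 1 `CC(=O)N1N=C(Nc2nc3ccc(Cl)cc3s2)CC1c1ccccc1`: 161 umol/kg
- Compound 2 `CC(=O)N1N=C(Nc2nc3ccc(C)cc3s2)CC1c1ccc(O)cc1`: 50.2 umol/kg
- Compound 3 `CC(=O)N1N=C(Nc2nc3ccccc3s2)CC1c1ccccc1`: 315 umol/kg

Compound 3 lies within the scatter of compound 1 and at a clearly higher number than compound 2. Compound 4 `CC(=O)N1N=C(Nc2nc3ccc(C)cc3s2)CC1c1ccccc1` has methyl in place of hydrogen on an aromatic carbon. The closest measured change is hydrogen in place of chloro on an aromatic carbon, a 2.0-fold higher number from compound 1 to compound 3 (0.29 log units; within the scatter). Compound 2 also carries the methyl, but it differs from compound 3 in a second place as well, so its value does not isolate this change. No step beyond the scatter is therefore expected in this assay, though a slightly lower number is possible. The expected change is a 1.6-fold lower number from compound 3 to compound 4 (0.20 log units; within the scatter). Compound 4 is estimated at 200 umol/kg, with an expected range from 90 umol/kg to 400 umol/kg.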

Compound 4, dose for half-maximal effect: 106 umol/kg
For compound 4 the middle estimate is 1.9-fold (0.28 log units) above the measured one, within the range that was stated.
By their numbers in this assay, from the lowest: compound 2; then compounds 4, 1 and 3 (each within the scatter of the next, the first and the last beyond it).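

In this assay, methyl on this aromatic carbon gives a step beyond the scatter (a 3.0-fold lower number from compound 3 to compound 4 (0.47 log units; beyond the scatter)), whereas the earlier step between chloro and hydrogen at this place stayed within it. Methyl and chloro cannot be told apart here (a 1.5-fold lower number from compound 1 to compound 4 (0.18 log units; within the scatter)). With the methyl in place, losing the hydroxy also gives a modest step beyond the scatter (a 2.1-fold higher number from compound 2 to compound 4 (0.32 log units; beyond the scatter)). As far as these compounds go, whether an amine or a methoxy group at the methyl's place would go with methyl or with hydrogen remains open. Nothing given here explains these steps.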